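Ring for Chain on the Aryl Ether of Compound 2

This account rests on a few compounds, and the source may have more. Where it says the series, first, only, none or still open, it means among the compounds named here.

Of the compounds shown here, three share a core and have been measured in an assay on CHO cells with Alpha-2B adrenergic receptor (Homo sapiens) as the target; a higher number here means a larger maximal response, a lower number a smaller maximal response. Compound 1 `CCOc1ccccc1OC(C)C1=NCCN1` gives 0.5. Compound 2 `CC(C)Oc1ccccc1OC(C)C1=NCCN1` gives 0.5, so that no change at the digits printed from compound 1 to compound 2 (within the scatter); compound 2 therefore stands level with compound 1 and together they are the lowest of the three. Among the measured compounds shown here, compound 3 `C=CCc1cccc(CC=C)c1OC(C)C1=NCCN1` gives 0.65, the only value that lies beyond the scatter from compound 2.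

Compound 4 `CC(Oc1ccccc1OC1CC1)C1=NCCN1` has not yet been measured. It differs from compound 2 in this way: cyclopropyl in place of isopropyl on an oxygen on an aromatic ring. For the measured compounds named here, the only measured step, the one from compound 1 to compound 2, concerns a different place on the molecule and showed no change; no measured step alters the group on the oxygen on the aromatic ring, so no direct precedent exists. With nothing pointing either way, compound 4 is expected to show no step beyond the scatter, that is no change at the digits printed from compound 2 to compound 4 (within the scatter). Compound 4 is thus estimated at 0.5, between 0.35 and 0.65.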

Compound 4, intrinsic activity: the largest response reached, as a fraction of the reference agonist's: 0.6
Compound 4: the middle estimate sits 0.10 below what was measured, and the stated range covers the measured number.
By their numbers in this assay, from the lowest: compounds 1, 2, 4 and 3 (each within the scatter of the next, the first and the last beyond it).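

At the oxygen on the aromatic ring, the compounds now show a change to the group itself: in this assay, cyclopropyl in place of isopropyl gives a number 0.10 higher from compound 2 to compound 4 (within the scatter), and cyclopropyl in place of ethyl gives a number 0.10 higher from compound 1 to compound 4 (within the scatter). Across these three compounds, then, an open chain and a three-membered carbon ring on this oxygen lie within the scatter of one another, and isopropyl and cyclopropyl have the same count of heavy atoms. Nothing at hand explains why the ring and the chains read alike here.

Going by these compounds, it remains open whether a larger ring such as cyclopentyl, a longer chain such as n-butyl, or an amine on this oxygen would take the maximal response beyond the scatter. Also open, on these data alone, is whether a phenyl group there would do so.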